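From 3-chlorophenyl to 3-aminophenyl on the shared core

The source may hold more compounds than are shown below. What is called first, only, known or untested is meant among the compounds shown, and "the series" means these compounds.

In a functional assay on A549 cells (Homo sapiens) for antiproliferative activity, read by MTT assay, with a stated time of 72 h (a higher number here means a weaker inhibitor, a lower number a stronger inhibitor), compound 1 `CCOc1ccc(-c2ccc3ncn(-c4cc(OC)c(OC)c(OC)c4)c3c2)cc1` gives 8550 nM and compound 2 `COc1cc(-n2cnc3ccc(-c4cccc(Cl)c4)cc32)cc(OC)c1OC` gives 7050 nM, two values within the scatter of each other. Compound 3 `COc1cc(-n2cnc3ccc(-c4cccc(N)c4)cc32)cc(OC)c1OC` carries amino in place of chloro on an aromatic carbon. Among the compounds with values here, the only measured step, a 1.2-fold lower number from compound 1 to compound 2 (0.08 log units; within the scatter), exchanges the aryl group at this same place and stays within the scatter. Within the data shown here, no measured compound carries amino, so no step beyond the scatter is expected in this assay, and the estimated change is a 1.2-fold lower number from compound 2 to compound 3 (0.07 log units; within the scatter). For compound 3 the expected value is 6000 nM, with an estimated range of 1800 nM to 18000 nM.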

Compound 3, half-maximal inhibitory concentration: 640 nM
Estimate against measurement, compound 3: 9.4-fold (0.97 log units) above; the measured number lies below the stated range.
By their numbers in this assay, from the lowest: compound 3; then compounds 2 and 1 (each within the scatter of the next).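

In this assay this place on the aryl group proves sensitive: amino in place of chloro gives a large step (an 11-fold lower number from compound 2 to compound 3 (1.04 log units; beyond the scatter)), whereas the earlier exchange of aryl groups stayed within the scatter (a 1.2-fold lower number from compound 1 to compound 2 (0.08 log units; within the scatter)). The 3-aminophenyl compound also stands clear of the 4-ethoxyphenyl compound (a 13-fold lower number from compound 1 to compound 3 (1.13 log units; beyond the scatter)). No measurement shown here accounts for the step.

On these data alone, whether the gain belongs to amino alone remains open. A hydroxyl, a methylamino or an acetamide group at this place would test that.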